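This account rests on a few compounds, and the source may have more. Where it says the series, first, only, none or still open, it means among the compounds named here.

Measured in a functional assay on HT-29 cells (Homo sapiens) for inhibition, read by luminescence and CellTiter-Glo, with a stated time of 24 h; a higher number here means that more compound is needed for the effect, a lower number that less compound is needed:
- Compound 1 `CCCn1nc(C(=O)N[C@H]2COc3ccccc3N(C)C2=S)nc1Cc1ccccc1`: 288 nM
- Compound 2 `CCCCn1nc(C(=O)N[C@H]2COc3ccccc3N(C)C2=S)nc1Cc1ccccc1`: 510 nM
- Compound 3 `CN1C(=S)[C@@H](NC(=O)c2nc(Cc3ccccc3)n(CCCO)n2)COc2ccccc21`: 209 nM

Compound 3 stands level with compound 1 and apart from compound 2. The two steps that show this are a 1.4-fold lower number from compound 1 to compound 3 (0.14 log units; within the scatter) and a 2.4-fold lower number from compound 2 to compound 3 (0.39 log units; beyond the scatter).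

Compound 4 `CN1C(=S)[C@@H](NC(=O)c2nc(Cc3ccccc3)n(C3CCCC3)n2)COc2ccccc21` puts cyclopentyl in place of 3-hydroxypropyl on an aromatic nitrogen. The measured steps that bear on this change all sit on the same chain, and they are small. One is a 1.8-fold higher number from compound 1 to compound 2 (0.25 log units; within the scatter), and the largest is the step from compound 2 given above. Among the measured compounds shown here, none of the measured compounds has a ring at this place, so the data offer only a rough guide.

Compound 2 has no hydroxy group on its chain and carries 510 nM, which points to a modest rise rather than a large change. In this assay, the expected result is a 1.9-fold higher number from compound 3 to compound 4 (0.28 log units; within the scatter). The estimate for compound 4 is 400 nM, with an expected range from 120 nM to 1300 nM.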

Compound 4, half-maximal effective concentration: 3530 nM
Compound 4: middle estimate off by 8.8-fold (0.95 log units), on the low side; the whole stated range lies below it.
By their numbers in this assay, from the lowest: compounds 3, 1 and 2 (each within the scatter of the next, the first and the last beyond it); then compound 4.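

In this assay, replacing an open chain on this aromatic nitrogen with cyclopentyl matters far more than lengthening the chain or adding a hydroxy group to it, and the rise appears against all three chains: a 17-fold higher number from compound 3 to compound 4 (1.23 log units; beyond the scatter), a 12-fold higher number from compound 1 to compound 4 (1.09 log units; beyond the scatter) and a 6.9-fold higher number from compound 2 to compound 4 (0.84 log units; beyond the scatter). Losing the hydroxy group cannot alone account for the rise, as compound 1 and compound 2 also lack it and still stand well apart from compound 4. No measurement offered here explains this gap.

The compounds shown leave open whether the rise belongs to rings at this place in general or to cyclopentyl alone, which cyclopropyl or a piperidine ring could test. Also open, from the compounds shown here alone, is how a longer chain, or a chain ending in an amine or a carboxylic acid, would compare.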